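Swapping acetyl for tert-butyl: a cytotoxicity forecast

The compounds below may be only part of what the source reports. "The series", "measured", "known", "first", "only" and "open" are said of these compounds alone.

Measured compounds:
- compound 1, `CCSc1ccc(-c2nccc3[nH]c(C(C)(C)O)cc23)cc1`: 17200 nM
- compound 2, `CC(=O)c1ccc(-c2nccc3[nH]c(C(C)(C)O)cc23)cc1`: "not determined" (no result reported)
- compound 3, `CC(C)(O)c1cc2c(-c3ccc(NC(=O)OCc4ccccc4)cc3)nccc2[nH]1`: 5500 nM

Three compounds sharing one core were tested in an ADME assay on U2OS cells (Homo sapiens) for cytotoxicity; on this read-out lower numbers stand for higher toxicity in this test and higher numbers for lower toxicity in this test. Compound 1 gives 17200 nM and compound 3 gives 5500 nM. For compound 2 the outcome is "not determined" (no result reported), so compound 2 stands nowhere on these values and offers no anchor of its own. Compound 4, `CC(C)(C)c1ccc(-c2nccc3[nH]c(C(C)(C)O)cc23)cc1`, differs from compound 2 by tert-butyl in place of acetyl on an aromatic carbon. Among the compounds with values here, with no measured step available, the expected size of the change in this assay cannot be taken from the data; the two neighbouring values suggest only a modest range. Compound 4 is expected to give about 15000 nM, most likely between 5000 nM and 40000 nM.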

Compound 4, half-maximal cytotoxic concentration: 35300 nM
The estimate for compound 4 lay 2.4-fold (0.37 log units) below the measured number, and the stated range covers the measured number.
By their numbers in this assay, from the lowest: compound 3; then compound 1; then compound 4.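

In this assay, within the data shown here, the group on this aromatic carbon does change the number: tert-butyl in place of ethylsulfanyl gives a 2.1-fold higher number from compound 1 to compound 4 (0.31 log units; beyond the scatter) and is the first measured step at this position. The swap of acetyl for tert-butyl itself cannot be read, since compound 2 has no number. Nothing available accounts for the step. Still open, on these data alone, is how an amine or a carboxylic acid on this carbon would compare, and whether a longer chain than tert-butyl would move the number further.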